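The source may hold more compounds than are shown below. What is called first, only, known or untested is meant among the compounds shown, and "the series" means these compounds.

Of the compounds shown here, three have so far been measured in an ADME assay on MT4 cells (Homo sapiens) for cytotoxicity, read by spectrophotometry, with a stated time of 5 days; a higher number here means that more compound is tolerated, a lower number that less compound is tolerated. In this assay compound 1 `CCn1cc(C(=O)O)c(=O)c2cc(F)c(N3CCN(CN4C(=O)/C(=N\NC(=S)NO)c5cc(F)ccc54)CC3)cc21` gives 208000 nM, and compound 2 `CCn1cc(C(=O)O)c(=O)c2cc(F)c(N3CCN(CN4C(=O)/C(=N\NC(=S)NO)c5cc(Cl)ccc54)CC3)cc21` gives 186000 nM. Compound 2 differs from compound 1 only by chloro in place of fluoro on an aromatic carbon, and this change gave a 1.1-fold lower number from compound 1 to compound 2 (0.05 log units; within the scatter). Compound 3 `CCN(CC)CN1C(=O)/C(=N\NC(=S)NOC)c2cc(F)ccc21` gives 490000 nM in this assay, the highest of the three numbers; how its core differs from the core of compound 1 is not broken down here. Compound 4 `CCN(CC)CN1C(=O)/C(=N\NC(=S)NOC)c2cc(Cl)ccc21` has not yet been measured. It differs from compound 3 by chloro in place of fluoro on an aromatic carbon, the same change, at the same place, as from compound 1 to compound 2. That earlier step lay within the scatter, so a similarly small shift is expected here. Compound 4 is accordingly expected to show a step of a 1.1-fold lower number from compound 3 to compound 4 (0.04 log units; within the scatter). The estimate for compound 4 in this assay is 450000 nM, with a likely range from 250000 nM to 800000 nM.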

Compound 4, half-maximal cytotoxic concentration: 454000 nM
The estimate for compound 4 lay 1.0-fold (0.00 log units) below the measured number; the range from low to high includes it.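

In this assay chloro in place of fluoro on an aromatic carbon gave a 1.1-fold lower number from compound 3 to compound 4 (0.03 log units; within the scatter) and so made no change that stands out from the scatter. On the two cores shown, this swap at the same place gave steps of matching small size: the same change on two cores in this assay, a 1.1-fold lower number (0.05 log units; within the scatter) from compound 1 to compound 2 and a 1.1-fold lower number (0.03 log units; within the scatter) from compound 3 to compound 4, 1.0-fold (0.02 log units) apart, within the scatter of two such steps. This shows that the result carried over between these two cores, but two pairs make no general rule, and it does not show what would happen on another core or at another place on the ring.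

The compounds shown leave open what a different group at this place, such as bromo, methoxy or a nitrile, would do to the number. They also leave open whether the hydrogen-free swap seen here would stay as small with an amine or a longer chain elsewhere on the core.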